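Chloro for cyano: from compound 2 to compound 4

This account rests on a few compounds, and the source may have more. Where it says the series, first, only, none or still open, it means among the compounds named here.

Three compounds of the series carry numbers in a functional assay on CHO cells for antagonist activity at Orexin/Hypocretin receptor type 1 (Homo sapiens), read by FLIPR and calcium flux; on this read-out higher numbers stand for higher potency (the scale is a negative logarithm) and lower numbers for lower potency. Compound 1 `O=C(c1cc(Cl)ccc1-c1ncccn1)N1CC2(CC2)C[C@H]1CNc1cc(C(F)(F)F)ccn1` gives 8.1. Compound 2 `N#Cc1ccc(-c2ncccn2)c(C(=O)N2CC3(CC3)C[C@H]2CNc2ccc(C(F)(F)F)cn2)c1` gives 8. Compound 3 `Cc1ccc(-n2nccn2)c(C(=O)N2CCC3(CC3)C[C@H]2CNc2ccc(Cl)cn2)c1` gives 7.5. Compound 2 stands second highest of these three numbers; its nearest neighbour is compound 1, whose number is higher by an amount within the scatter, and its furthest is compound 3, whose number is lower by an amount beyond the scatter.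

Compound 4 `O=C(c1cc(Cl)ccc1-c1ncccn1)N1CC2(CC2)C[C@H]1CNc1ccc(C(F)(F)F)cn1` has not yet been measured in this assay. It differs from compound 2 in a single place: chloro in place of cyano on an aromatic carbon. Within the data shown here, no measured pair of the series shows this exchange on its own, so the step has to be judged from the neighbours. Compound 1 carries the same chloro group and its value 8.1 lies within the scatter of compound 2. For the exchange from cyano to chloro, no step beyond the scatter is expected in this assay; the expected step is no change at the digits printed from compound 2 to compound 4 (within the scatter). Compound 4 is accordingly estimated at 8, with a range from 7.5 to 8.5.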

Compound 4, negative logarithm of the antagonist equilibrium constant: 8.1
Estimate against measurement, compound 4: 0.10 log units below; the range from low to high includes it.
By their numbers in this assay, from the lowest: compound 3; then compounds 2, 1 and 4 (each within the scatter of the next).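

In this assay the exchange at the aromatic carbon para to a pyrimidin-2-yl group can now be read directly: a number 0.10 log units higher from compound 2 to compound 4 (within the scatter), so cyano and chloro are not told apart at this position in this pair. The second exchange, 5-(trifluoromethyl)pyridin-2-yl in place of 4-(trifluoromethyl)pyridin-2-yl on an amine nitrogen, gives no change at the digits printed from compound 1 to compound 4 (within the scatter), so these two pyridinyl groups are not told apart either while chloro stays on the aromatic ring. Nothing at hand accounts for either result.

The compounds shown leave open whether a carboxylic acid or an amine at that same aromatic carbon would stay within the scatter of compound 4. They also leave open whether a methoxy group in place of trifluoromethyl on the pyridine would do so.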